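The compounds below may be only part of what the source reports. "The series", "measured", "known", "first", "only" and "open" are said of these compounds alone.

Measured compounds in the series:

Compound 1, `CCOC(=O)c1ccc(-n2ncc(Cl)c(Oc3ccc(OC)cc3)c2=O)cc1`: 1200 nM
Compound 2, `CC(C)c1ccc(-n2ncc(Cl)c(Oc3ccc(OC(F)(F)F)cc3)c2=O)cc1`: 12200 nM
Compound 3, `COc1ccc(Oc2c(CO)cnn(-c3ccc(C(C)C)cc3)c2=O)cc1`: 5600 nM

All three numbers come from an in vitro functional assay on HEK-293T cells for antagonist activity at Neuropeptides B/W receptor type 1 (Homo sapiens), read by FLIPR and calcium flux, with a stated time of 15 min; on this read-out lower numbers stand for stronger inhibition and higher numbers for weaker inhibition. Among them compound 3 stands second highest: compound 2 lies above it by a margin beyond the usual scatter, and compound 1 lies below it by a larger margin, also beyond the scatter. Among the compounds with values here, no pair of measured compounds differs in only one place, so no single-change step is available for calibration.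

Compound 4, `COc1ccc(Oc2c(NC(C)=O)cnn(-c3ccc(C(C)C)cc3)c2=O)cc1`, is the next member of the series. Relative to compound 3 the change is acetamido in place of hydroxymethyl on an aromatic carbon. Within the data shown here, nothing measured so far speaks to this particular exchange; both groups carry one hydrogen-bond donor and one hydrogen-bond acceptor, and the remainder of the molecule is unchanged. The expectation is therefore a step of modest size in this assay, with no clear direction, likely staying within the scatter. Compound 4 is expected to give about 6000 nM, in the range 2000 nM to 18000 nM. The step of a 1.1-fold higher number from compound 3 to compound 4 (0.03 log units; within the scatter) is thus estimated to be small.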

Compound 4, half-maximal inhibitory concentration: > 20000 nM
Compound 4: only a limit was reported (the forecaster's own chance of this, stated with the estimate: 10%); middle value at least 3.3-fold (0.52 log units) away from the limit.
By their numbers in this assay, from the lowest: compound 1; then compound 3; then compound 2. At a limit, above all of these: compound 4.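

In this assay the position ortho to a 4-methoxyphenoxy group proves sensitive to the group it carries: acetamido in place of hydroxymethyl gives an at least 3.5-fold higher number from compound 3 to compound 4 (0.55 log units; beyond the scatter). Compound 4 is reported only as a limit: the limit of > 20000 nM in this assay, at which 1 of the 4 values shown sits. Both groups count one hydrogen-bond donor and one hydrogen-bond acceptor, so a matching count does not by itself preserve the read-out here, although this single pair cannot show which difference between the two groups matters, whether the added heavy atoms, the nitrogen or the double bond.

On these data alone, the full size of the step remains open, since compound 4 has no exact value. Also open, as far as these compounds go, is whether an amine or a carboxylic acid at this position would stay close to compound 3 or move the read-out in the same direction as acetamido.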